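This account rests on a few compounds, and the source may have more. Where it says the series, first, only, none or still open, it means among the compounds named here.

Compound 1 `CC(C)c1onc(-c2c(Cl)cccc2Cl)c1COc1ccc(-c2nc3ccc(C(=O)O)cc3n2Cc2ccc(F)cc2)cc1` carries a 4-fluorobenzyl group on an aromatic nitrogen of the shared core. In an assay on HEK-293T cells for antagonist activity at vitamin D3 receptor (Homo sapiens), read by a luciferase reporter, with a stated time of 24 h (on this read-out higher numbers stand for weaker inhibition and lower numbers for stronger inhibition), compound 1 gives 1140 nM, the second highest of the three numbers recorded so far. Its nearest companion is compound 3 `CC(C)c1onc(-c2c(Cl)cccc2Cl)c1COc1ccc(-c2nc3ccc(C(=O)O)cc3n2C2CCCCCC2)cc1`, which in this assay gives 921 nM; the furthest is compound 2 `CC(C)c1onc(-c2c(Cl)cccc2Cl)c1COc1ccc(-c2nc3ccc(C(=O)O)cc3n2C2CC2)cc1`, which gives 3200 nM. The step of a 1.2-fold lower number from compound 1 to compound 3 (0.09 log units; within the scatter) stays within the scatter, whereas a 2.8-fold higher number from compound 1 to compound 2 (0.45 log units; beyond the scatter) and a 3.5-fold lower number from compound 2 to compound 3 (0.54 log units; beyond the scatter) both lie beyond it.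

Compound 4 `CC(C)c1onc(-c2c(Cl)cccc2Cl)c1COc1ccc(-c2nc3ccc(C(=O)O)cc3n2C2CCC2)cc1` has not yet been measured. It differs from compound 1 by cyclobutyl in place of 4-fluorobenzyl on an aromatic nitrogen. For the measured compounds named here, two measured steps bear on this change, since both replace the same 4-fluorobenzyl with a cycloalkyl ring on that nitrogen: cyclopropyl in compound 2 gave a 2.8-fold higher number from compound 1 to compound 2 (0.45 log units; beyond the scatter), and cycloheptyl in compound 3 gave a 1.2-fold lower number from compound 1 to compound 3 (0.09 log units; within the scatter). Cyclobutyl, a four-membered ring, lies between those two in ring size and nearer to cyclopropyl, so a modest rise in the number is expected, though a smaller one than was seen for compound 2. Compound 4 is therefore estimated to give 2200 nM in this assay, between 900 nM and 5000 nM. The expected step is thus a 1.9-fold higher number from compound 1 to compound 4 (0.29 log units; within the scatter).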

Compound 4, half-maximal inhibitory concentration: 1100 nM
Beside the measured number, compound 4's estimate is 2.0-fold (0.30 log units) above it; the range from low to high includes it.
By their numbers in this assay, from the lowest: compounds 3, 4 and 1 (each within the scatter of the next); then compound 2.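

In this assay, the cyclobutyl group shows that a small ring on this aromatic nitrogen need not raise the number: replacing 4-fluorobenzyl gives no change beyond the scatter (a 1.0-fold lower number from compound 1 to compound 4 (0.02 log units; within the scatter)), and neither does the comparison with cycloheptyl (a 1.2-fold higher number from compound 3 to compound 4 (0.08 log units; within the scatter)). Compound 2 now stands alone, since the change from cyclopropyl to cyclobutyl is beyond the scatter (a 2.9-fold lower number from compound 2 to compound 4 (0.46 log units; beyond the scatter)), so the number does not follow ring size in a graded way across these compounds and the rise seen earlier belongs to cyclopropyl alone. Nothing available explains why cyclopropyl differs from the other three groups.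

The compounds shown leave open whether an open chain such as isopropyl, or a chain ending in an amine or a hydroxyl group, would stay level with compounds 1, 3 and 4 on this nitrogen or move the number away from them. It also remains open whether the same levelling among these groups would hold if the carboxylic acid of the shared core gave way to a primary amide.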